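Dichlorophenyl in place of pyridinyl on the ring nitrogen

This account rests on a few compounds, and the source may have more. Where it says the series, first, only, none or still open, it means among the compounds named here.

Compound 2 `NC(=S)Nc1cccc(OCCCCCN2CCN(c3cccnc3)C2=O)c1` reaches only the limit > 50000 nM in an ADME assay on Huh-7 cells (Homo sapiens) for cytotoxicity (a higher number here means that more compound is tolerated, a lower number that less compound is tolerated), so no number is known for it. Compound 1 `NC(=S)Nc1cccc(OCCCCCN2CCN(c3cccc4ccccc34)C2=O)c1` gives 15000 nM in this assay. Among the compounds with values here, the single measured step, an at least 3.3-fold higher number from compound 1 to compound 2 (0.52 log units; beyond the scatter), runs up to the limit of > 50000 nM in this assay, at which 1 of the 2 values shown sits. Compound 3 `NC(=S)Nc1cccc(OCCCCCN2CCN(c3ccc(Cl)c(Cl)c3)C2=O)c1` carries 3,4-dichlorophenyl in place of pyridin-3-yl on an amide-type nitrogen in a ring. With the pyridin-3-yl gone and 3,4-dichlorophenyl entering, the change is expected to run in the direction opposite to the measured step, back toward compound 1, and beyond the scatter. Compound 3 is therefore estimated at 25000 nM, with a range from 8000 nM to 60000 nM. That expectation means a step of an at least 2.0-fold lower number from compound 2 to compound 3 (0.30 log units; that floor lies within the scatter).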

Compound 3, half-maximal cytotoxic concentration: 13000 nM
Compound 3: the middle estimate sits 1.9-fold (0.28 log units) above what was measured; low and high end bracket the measured number.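

In this assay, 3,4-dichlorophenyl in place of pyridin-3-yl gives an at least 3.8-fold lower number from compound 2 to compound 3 (0.58 log units; beyond the scatter). Set against naphthalen-1-yl, the same group gives a 1.2-fold lower number from compound 1 to compound 3 (0.06 log units; within the scatter), so the two carbon-only aromatic groups on the ring nitrogen cannot be told apart here, and compound 2 alone stands apart from both. Compound 2 remains a limit and not a number, so its step shows only a floor: the limit of > 50000 nM in this assay, at which 1 of the 3 values shown sits.

The compounds shown leave open whether a plain phenyl on this nitrogen would fall with compound 1 and compound 3 or with compound 2. Where a pyridin-3-yl carrying a chlorine would fall also stays open.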